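The source may report more compounds than this note shows. Statements on the series, on what has been measured and on what is new or still open speak of the compounds shown alone.

Measured so far:
compound 1, `C=CCc1cc2c(cc1O)C(C)(C)C(CCc1ccc(OC)cc1)O2`, 52 nM
compound 2, `C=CCc1cc2c(cc1O)CC(CCc1ccccc1)O2`, 17 nM

In an assay for inhibition of Polyunsaturated fatty acid 5-lipoxygenase (Rattus norvegicus) (on this read-out lower numbers stand for stronger inhibition and higher numbers for weaker inhibition), compound 2 gives 17 nM, the lowest of the two numbers shown. Compound 1 gives 52 nM in this assay, a higher number. Going by the values given here, the two compounds differ in more than one place, so no single step between them is defined; only their two values are known.

Compound 3, `Oc1cc2c(cc1CCCOc1ccccc1)OC(CCc1ccccc1)C2`, has not been measured. It differs from compound 2 in one place: 2-phenoxyethyl in place of vinyl on a saturated chain carbon bound to an aromatic carbon. Among the compounds with values here, no measured pair shows a change of this kind, so its effect on this assay can only be guessed. The phenolic hydroxyl and the benzofuran-type core with its phenethyl side chain are kept unchanged from compound 2, which argues for a number not far from that of compound 2. The step from compound 2 to compound 3 is therefore expected to be small, a 1.8-fold higher number from compound 2 to compound 3 (0.25 log units; within the scatter), with a wide range in either direction. For compound 3 the expected value in this assay is 30 nM, between 8 nM and 120 nM.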

Compound 3, half-maximal inhibitory concentration: 23 nM
For compound 3 the middle estimate is 1.3-fold (0.12 log units) above the measured one; low and high end bracket the measured number.
By their numbers in this assay, from the lowest: compounds 2 and 3 (each within the scatter of the next); then compound 1.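

In this assay, putting 2-phenoxyethyl in place of vinyl on a saturated chain carbon bound to an aromatic carbon gives a 1.4-fold higher number from compound 2 to compound 3 (0.13 log units; within the scatter). Going by these compounds alone, this is the only single-place step, and it shows that this position accepts a group of 9 heavy atoms, with a six-membered aromatic ring and a hydrogen-bond acceptor, in place of one of 2 heavy atoms with a double bond, and that the read-out stays within the scatter; compounds 1 and 2 differ in more than one place, so their values alone could not show this. No measurement shown bears on the reason for this tolerance.

The compounds shown do not separate the part played by the aromatic ring of 2-phenoxyethyl from that of its ether oxygen, which a plain propyl chain or a longer alkyl chain in this place would help to tell apart. As far as these compounds go, whether an amine or a carboxylic acid would be accepted here as well remains open, as does the upper limit on the size of the group at this position.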